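A few compounds are considered here, and "the series" means these few. Any claim that something is new, unique, unknown or untested is made for them only; others in the source may bear on it.

Compound 3 `O=C(O)C[C@H](O)C[C@H](O)CCn1c(-c2ccc(F)cc2)nc(C(=O)NCc2ccccc2)c1C1CC1` gives 1.4 nM in an assay on microsomes from liver for inhibition of 3-hydroxy-3-methylglutaryl-coenzyme A reductase (Rattus norvegicus), read by scintillation counting, with stated times of 0.5 h and 0.75 h (a lower number here means a stronger inhibitor, a higher number a weaker inhibitor), and is the second highest of three numbers. Compound 1 `COc1ccc(CNC(=O)c2nc(-c3ccc(F)cc3)n(CC[C@@H](O)C[C@@H](O)CC(=O)O)c2C2CC2)cc1` gives 1.2 nM and stands within the scatter of compound 3, since a 1.2-fold higher number from compound 1 to compound 3 (0.07 log units; within the scatter). Compound 2 `Cc1cccc(CNC(=O)c2nc(-c3ccc(F)cc3)n(CC[C@@H](O)C[C@@H](O)CC(=O)O)c2C2CC2)c1` gives 7.2 nM, and a 5.1-fold lower number from compound 2 to compound 3 (0.71 log units; beyond the scatter). Compound 4 `Cc1ccccc1CNC(=O)c1nc(-c2ccc(F)cc2)n(CC[C@@H](O)C[C@@H](O)CC(=O)O)c1C1CC1` differs from compound 3 by methyl in place of hydrogen on an aromatic carbon. Among the compounds with values here, the steps that bear on it are those involving compound 2, where a methyl on the same ring cost a 6.0-fold higher number from compound 1 to compound 2 (0.78 log units; beyond the scatter) and was recovered on removal as above. Methyl ortho to the large group has no direct precedent here, so a smaller rise than that seen for compound 2 is expected, though a rise beyond the scatter remains plausible. Compound 4 is estimated at 3.5 nM, with a range from 1.2 nM to 12 nM, meaning an expected 2.5-fold higher number from compound 3 to compound 4 (0.40 log units; beyond the scatter).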

Compound 4, half-maximal inhibitory concentration in the 3-hydroxy-3-methylglutaryl-coenzyme A reductase assay: 4.9 nM
The estimate for compound 4 lay 1.4-fold (0.15 log units) below the measured number; measured number inside the range.
By their numbers in the 3-hydroxy-3-methylglutaryl-coenzyme A reductase assay, from the lowest: compounds 1 and 3 (each within the scatter of the next); then compounds 4 and 2 (each within the scatter of the next).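

In the 3-hydroxy-3-methylglutaryl-coenzyme A reductase assay methyl on this ring now costs potency at a second place, with a 3.5-fold higher number from compound 3 to compound 4 (0.54 log units; beyond the scatter), while 2-methylphenyl and 3-methylphenyl are not separated, with a 1.5-fold lower number from compound 2 to compound 4 (0.17 log units; within the scatter). The 2-methylphenyl also falls short of the 4-methoxyphenyl, with a 4.1-fold higher number from compound 1 to compound 4 (0.61 log units; beyond the scatter), so compound 1 remains the only substituted ring here level with compound 3. In a physicochemical assay for lipophilicity, using the shake flask method, at pH 7.4 (a higher number here means a more lipophilic compound, a lower number a more polar compound), compound 3 gives 0.03 and compound 4 gives 0.44, so the same methyl raises this number too.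

As far as these compounds go, whether that rise is tied to the loss of potency stays open. From the compounds shown here alone, it is also open whether chlorine, hydroxyl or an amine at this place would be tolerated better than methyl.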